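A few compounds are considered here, and "the series" means these few. Any claim that something is new, unique, unknown or untested is made for them only; others in the source may bear on it.

Of the compounds shown here, three sharing one core have been tested in a functional assay on HL-60 cells (Homo sapiens) for inhibition, read by MTT assay, with a stated time of 48 h, tested at 10 uM; on this read-out higher numbers stand for more inhibition of growth at the one concentration tested and lower numbers for less inhibition of growth. Compound 1, `COc1ccc(COc2cc(O)c3c(=O)cc(C)oc3c2[C@H]2CCN(C)C[C@H]2O)cc1`, gives 23% in this assay. Compound 2, `CCOC(=O)N1CCN(Cc2c(O)c([C@H]3CCN(C)C[C@H]3O)c3oc(C)cc(=O)c3c2O)CC1`, gives 16%. Compound 3, `Cc1oc2c([C@H]3CCN(C)C[C@H]3O)c(O)cc(O)c2c(=O)c1C(O)c1ccc([N+](=O)[O-])cc1`, gives 0% and so stands lowest of the three; its gap to compound 2 and its gap to compound 1 both lie beyond the usual scatter of this measurement. Compounds 1 and 2 differ from compound 3 in more than one place, so no single structural change can be tied to any of these gaps.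

The next compound, compound 4, `Cc1oc2c([C@H]3CCN(C)C[C@H]3O)c(O)cc(O)c2c(=O)c1C(O)c1cccc(Cl)c1Cl`, differs from compound 3 in only one place: 2,3-dichlorophenyl in place of 4-nitrophenyl on a saturated chain carbon bound to an aromatic carbon and an oxygen on a saturated carbon. Among the compounds with values here, no pair of measured compounds shows this change, so there is no measured step to lean on. With compound 3 already showing no growth inhibition, a drop is impossible, and a swap of one aromatic ring for another at the same place gives no reason to expect a large rise. For compound 4 the expected step is therefore a number 8 percentage points higher from compound 3 to compound 4 (within the scatter), a change that would remain within the scatter. Compound 4 is expected to reach about 8% in this assay, with a plausible range from 0% to 25%.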

Compound 4, percent growth inhibition at one concentration: 12%
Compound 4: middle estimate off by 4 percentage points, on the low side, within the range that was stated.
By their numbers in this assay, from the lowest: compound 3; then compounds 4, 2 and 1 (each within the scatter of the next, the first and the last beyond it).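

Within the data shown here, at the saturated chain carbon bound to an aromatic carbon and an oxygen on a saturated carbon, this is the first pair of compounds that differ in only one place, so a change in the number can be tied to a single structural swap. Putting 2,3-dichlorophenyl in place of 4-nitrophenyl gives, in this assay, a number 12 percentage points higher from compound 3 to compound 4 (beyond the scatter), a modest step showing that the aromatic ring at this place does affect the read-out, although compound 4 reaches only 12%. Nothing measured here accounts for this step, so the reason for it remains unknown.

A single swap removes the 4-nitrophenyl ring and brings in the 2,3-dichlorophenyl ring at once, so this pair cannot tell whether losing the former or gaining the latter matters more. It also remains open how a plain phenyl ring, an aminophenyl ring or a saturated ring such as cyclohexyl would read at this place, and whether the step would hold on the other cores shown.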